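Halogen to methoxy on the pendant phenyl ring

The source may hold more compounds than are shown below. What is called first, only, known or untested is meant among the compounds shown, and "the series" means these compounds.

Measured compounds:
Compound 1, `CCOc1nc(-c2cc3ccccc3o2)cc(-c2ccc(Cl)cc2)c1C#N`: 221000 nM
Compound 2, `CCOc1nc(-c2cc3ccccc3o2)cc(-c2ccc(F)cc2)c1C#N`: 396000 nM

Both numbers come from a functional assay on aorta (strain Wistar) for inhibition, with Thoracic aorta (Rattus norvegicus) as the target; a higher number here means a weaker inhibitor, a lower number a stronger inhibitor. Compound 1 gives 221000 nM and compound 2 gives 396000 nM in this assay. Among the compounds with values here, the one step between them, a 1.8-fold higher number from compound 1 to compound 2 (0.25 log units; within the scatter), does not separate the two; compound 2 stands together with compound 1, and no order between them can be read from these numbers.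

Compound 3, `CCOc1nc(-c2cc3ccccc3o2)cc(-c2ccc(OC)cc2)c1C#N`, has not yet been measured in this assay. It differs from compound 2 by methoxy in place of fluoro on an aromatic carbon. Within the data shown here, no measured step involves a methoxy group, so the only step available, a 1.8-fold higher number from compound 1 to compound 2 (0.25 log units; within the scatter), bears on this change only indirectly: it shows that exchanging one substituent for another at this position of the phenyl ring left the number within the scatter. On that basis no step beyond the scatter is expected from compound 2 to compound 3, though the absence of a methoxy precedent leaves the range wide.

For compound 3 the expected value in this assay is 350000 nM (range 120000 nM to 1000000 nM), which corresponds to an expected step of a 1.1-fold lower number from compound 2 to compound 3 (0.05 log units; within the scatter).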

Compound 3, half-maximal inhibitory concentration: 204000 nM
The estimate for compound 3 lay 1.7-fold (0.23 log units) above the measured number; low and high end bracket the measured number.
By their numbers in this assay, from the lowest: compounds 3, 1 and 2 (each within the scatter of the next).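

In this assay, within the data shown here, the 4-fluorophenyl to 4-methoxyphenyl change gives the first exchange at this position that goes beyond one halogen for another, and it gives a 1.9-fold lower number from compound 2 to compound 3 (0.29 log units; within the scatter), while methoxy in place of chloro gives a 1.1-fold lower number from compound 1 to compound 3 (0.03 log units; within the scatter). Both steps stay within the scatter, so replacing either halogen with methoxy does not separate the compounds, and compounds 1, 2 and 3 form a single group with no order among them. No separate data bear on why this exchange leaves the number within the scatter.

Still open, as far as these compounds go, is whether any substituent at this position can move the number beyond the scatter, for instance an amine, a carboxylic acid or a longer alkoxy chain in place of methoxy. The compounds shown also share the rest of the core, so they leave open whether a change elsewhere on it, such as an amide in place of the nitrile, would have a larger effect on the number than the three substituents compared here.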